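Removing a cyclopentyl group from an amide in two related cores

The source may hold more compounds than are shown below. What is called first, only, known or untested is meant among the compounds shown, and "the series" means these compounds.

Four compounds share a bicyclic core carrying an amide and differ in the group on that amide nitrogen and in the group on one ring nitrogen of the core. Compound 2 `CC[C@@H]1C(=O)N(C)c2cnc(-n3ccc4cc(C(=O)NC5CCCC5)ccc43)nc2N1C1CCCC1` and compound 1 `CC[C@@H]1C(=O)N(C)c2cnc(-n3ccc4cc(C(N)=O)ccc43)nc2N1C1CCCC1` have the same core; compound 1 arises from compound 2 through (hydrogen in place of cyclopentyl on an amide-type nitrogen). In a functional assay on NCI-H1975 cells (Homo sapiens) for antiproliferative activity, read by CCK-8 assay, with a stated time of 72 h (a higher number here means a weaker inhibitor of growth, a lower number a stronger inhibitor of growth), compound 2 gives 856 nM, while compound 1 gives 3380 nM, so this change made the step of a 3.9-fold higher number from compound 2 to compound 1 (0.60 log units; beyond the scatter).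

Compound 3 `CCC1C(=O)N(C)c2cnc(-n3ccc4cc(C(=O)NC5CCCC5)ccc43)nc2N1c1ccn(C)n1` carries the same cyclopentyl amide on a different core; the difference between the two cores is not broken down here. In this assay compound 3 is reported as "not active" (no number reported). Compound 4 `CCC1C(=O)N(C)c2cnc(-n3ccc4cc(C(N)=O)ccc43)nc2N1c1ccn(C)n1` arises from compound 3 through (hydrogen in place of cyclopentyl on an amide-type nitrogen), the same change as from compound 2 to compound 1, at a place described in the same words.

Since the change weakened growth inhibition on the first core, and compound 3 already shows no activity, compound 4 is expected to be at best weakly active in this assay, with an estimated value near 30000 nM, and most likely reported only as a limit.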

Compound 4, concentration for 50% growth inhibition: "not active" (no number reported)
No number was reported for compound 4; no gap can be computed for the estimate.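

In this assay compound 3 gives "not active" (no number reported) and compound 4 gives "not active" (no number reported) so no step can be read between these two compounds. The compounds shown leave open whether replacing cyclopentyl with hydrogen on the amide nitrogen changes growth inhibition at all on this core. No evidence bearing on this result is available.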